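Replacing 4-methylphenyl with 3-chlorophenyl on the shared core

This account rests on a few compounds, and the source may have more. Where it says the series, first, only, none or still open, it means among the compounds named here.

Of the compounds shown here, three on a shared core have numbers so far in a functional assay on B16 cells (Mus musculus) for cytotoxicity, read by CCK-8 assay, with a stated time of 24 h (on this read-out higher numbers stand for weaker inhibition and lower numbers for stronger inhibition), for comparison. Compound 1 (`COc1ccccc1Oc1c(N)nc(-c2cccc(Cl)c2)nc1Cl`) stands at 17900 nM and compound 2 (`COc1ccccc1Oc1c(N)nc(Cc2ccccc2)nc1OCCO`) at 47400 nM in this read-out. Compound 3 (`COc1ccccc1Oc1c(N)nc(-c2ccc(C)cc2)nc1OCCO`) gives 8430 nM as the lowest of the three numbers, and its gaps to both others lie beyond the scatter.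

Compound 4 (`COc1ccccc1Oc1c(N)nc(-c2cccc(Cl)c2)nc1OCCO`) has yet to be measured. It differs from compound 3 in one place (3-chlorophenyl in place of 4-methylphenyl on an aromatic carbon), with 3-chlorophenyl in place of 4-methylphenyl on an aromatic carbon between two ring nitrogen atoms. Among the measured compounds shown here, the only measured step at this place (a 5.6-fold lower number from compound 2 to compound 3 (0.75 log units; beyond the scatter)) was modest, and it replaced benzyl rather than a substituted phenyl. For the measured compounds named here, compound 1 carries 3-chlorophenyl but lacks the 2-hydroxyethoxy group, so no measured step isolates this change. Only a small shift in this assay is therefore expected, probably none beyond the scatter (a 1.1-fold higher number from compound 3 to compound 4 (0.03 log units; within the scatter)). Compound 4 is estimated at 9000 nM (expected range 4000 nM to 20000 nM).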

Compound 4, half-maximal inhibitory concentration: 5010 nM
Estimate against measurement, compound 4: 1.8-fold (0.25 log units) above, within the range that was stated.
By their numbers in this assay, from the lowest: compounds 4 and 3 (each within the scatter of the next); then compound 1; then compound 2.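

In this assay, 3-chlorophenyl in place of 4-methylphenyl gives a 1.7-fold lower number from compound 3 to compound 4 (0.23 log units; within the scatter) and so does not separate these two substituted phenyl groups on the aromatic carbon between two ring nitrogen atoms. With 3-chlorophenyl in place of benzyl, the change is a 9.5-fold lower number from compound 2 to compound 4 (0.98 log units; beyond the scatter) and joins a 5.6-fold lower number from compound 2 to compound 3 (0.75 log units; beyond the scatter) in showing that both phenyl groups give lower numbers than benzyl at this place. Among the compounds shown here, the result also isolates the other position for the first time: with 3-chlorophenyl held constant, 2-hydroxyethoxy in place of chloro gives a 3.6-fold lower number from compound 1 to compound 4 (0.55 log units; beyond the scatter) in this read-out.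

No supporting data explain any of these steps. As far as these compounds go, it remains open how a morpholine or a carboxylic acid in place of 2-hydroxyethoxy, or a 3-fluorophenyl in place of 3-chlorophenyl, would read in this assay on the shared core.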